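Growth inhibition series: methylation of an aromatic nitrogen

The source may report more compounds than this note shows. Statements on the series, on what has been measured and on what is new or still open speak of the compounds shown alone.

compound 1 `CCOC(=O)/C=C/c1ccncc1-c1ccc2[nH]ccc2c1` — in a functional assay on MCF7 cells (Homo sapiens) for inhibition, read by sulforhodamine B assay, with a stated time of 72 h (on this read-out lower numbers stand for stronger inhibition of growth and higher numbers for weaker inhibition of growth), compound 1 gives only a limit, > 10000 nM.
compound 2 `O=C(O)/C=C/c1ccncc1-c1ccc2cc[nH]c2c1` — in this assay compound 2 gives only a limit, > 10000 nM.
compound 3 `NC(=O)/C=C/c1ccncc1-c1ccc2ccccc2c1` — in this assay compound 3 gives only a limit, > 10000 nM.

Compound 1 stands at the assay limit, with no numerical value; the same holds for every entry in the set, as the limit of > 10000 nM in this assay, at which 3 of the 3 values shown sit, shows. For the measured compounds named here, no step between measured compounds is available, so no measured effect of any structural change can be drawn from these numbers.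

Compound 4 `CCOC(=O)/C=C/c1ccncc1-c1ccc2c(ccn2C)c1` differs from compound 1 by methyl in place of hydrogen on an aromatic nitrogen. With nothing measured below the limit, no step beyond the scatter in either direction is expected in this assay; the expected step from compound 1 to compound 4 is a step that the limit leaves unreadable from compound 1 to compound 4. Compound 4 is estimated at 15000 nM, between 5000 nM and 50000 nM, and is most probably reported again only as a limit.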

Compound 4, concentration for 50% growth inhibition: 8670 nM
Estimate against measurement, compound 4: 1.7-fold (0.24 log units) above, within the range that was stated.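

For the compounds shown here, compound 4 is the first entry in this assay with a number rather than a limit, so methyl on the aromatic nitrogen gives a readable value where the compound 1 entry gave none. The change reads as an at least 1.1-fold lower number from compound 1 to compound 4 (0.06 log units; that floor lies within the scatter) and so establishes no gain in growth inhibition. The step stays a floor, not a size, because compound 1 has only a limit: the limit of > 10000 nM in this assay, at which 3 of the 4 values shown sit.

Open, on these data alone, is whether a longer chain such as ethyl or benzyl on that nitrogen keeps a value under the limit. Also open, as far as these compounds go, is whether an amine in place of the ethyl ester does so.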